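The compounds below may be only part of what the source reports. "The series", "measured", "known", "first", "only" and "open" are said of these compounds alone.

Measured so far:
compound 1 `COc1cccc(OC)c1OCCNC[C@H]1Oc2ccccc2O[C@@H]1C` — 11.5 nM
compound 2 `COc1cccc(OC)c1OCCNC[C@H]1Oc2ccccc2O[C@H]1C1CCCCC1` — 631 nM

In a functional assay for antagonist activity at Adrenergic receptor alpha-1 (Rattus norvegicus) (on this read-out higher numbers stand for weaker binding and lower numbers for tighter binding), compound 2 gives the higher of the two numbers, with compound 1 giving 11.5 nM, a gap that lies beyond the scatter. Compound 3 `COc1cccc(OC)c1OCCNC[C@H]1Oc2ccccc2O[C@@H]1C1CCCCC1` differs from compound 2 in this way: the two compounds have the same atoms and bonds and differ only in configuration as drawn: 1 of 2 stereo elements differ; a stereocentre at a saturated ring carbon is drawn S in compound 2 and R in compound 3. Within the data shown here, no measured pair shows what such a change of configuration does here, so the size of the step is open. With nothing better than a diastereomer swap to go on, compound 3 is expected to sit somewhat lower, by about a 2.5-fold lower number from compound 2 to compound 3 (0.40 log units; beyond the scatter), though a change in either direction would not surprise. Compound 3 is thus estimated at 250 nM, within 40 nM to 1600 nM.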

Compound 3, dissociation constant: 813 nM
For compound 3 the middle estimate is 3.3-fold (0.51 log units) below the measured one; low and high end bracket the measured number.
By their numbers in this assay, from the lowest: compound 1; then compounds 2 and 3 (each within the scatter of the next).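

In this assay, swapping S for R at this saturated ring carbon with cyclohexyl attached gives a 1.3-fold higher number from compound 2 to compound 3 (0.11 log units; within the scatter), so this configuration does not separate the pair, whose only difference is this: the fact that compounds 2 and 3 differ only in the configuration as drawn. Cyclohexyl in place of methyl on this carbon gives a 71-fold higher number from compound 1 to compound 3 (1.85 log units; beyond the scatter), so the large gap goes with the change of group rather than with the configuration at this carbon. As far as these compounds go, what an ethyl or a phenyl group here would give stays open, as does whether the methyl compounds are equally indifferent to configuration.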